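The source may hold more compounds than are shown below. What is called first, only, known or untested is meant among the compounds shown, and "the series" means these compounds.

Working notes on the dihydropyridine ester series.

Compound 1 `CC1=C(C(=O)OCC2CCN(C(=O)OC(C)(C)C)CC2)C(c2cc(Cl)cc(Cl)c2)C2=C(CC(C)(C)CC2=O)N1` gives 640 nM in an assay on HEK293 cells for inhibition of neurogenic locus notch homolog protein 1 (Homo sapiens), read by a luciferase reporter and resazurin assay, with a stated time of 16 h; a lower number here means a stronger inhibitor, a higher number a weaker inhibitor. Compound 2 `CC1=C(C(=O)OCC2CCN(C(=O)OC(C)(C)C)CC2)C(c2cccc(C(C)C)c2)C2=C(CC(C)(C)CC2=O)N1` gives 3320 nM in this assay, and the step of a 5.2-fold higher number from compound 1 to compound 2 (0.71 log units; beyond the scatter) is the only one measured so far. Compound 2 thus stands at the highest of the two numbers, with compound 1 as its nearest neighbour.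

Compound 3 `CC1=C(C(=O)OCC2CCN(C(=O)OC(C)(C)C)CC2)C(c2ccc(-c3ccccc3)cc2)C2=C(CC(C)(C)CC2=O)N1` is the next point: 4-phenylphenyl in place of 3-isopropylphenyl on a saturated ring carbon. Going by the values given here, only the step from compound 1 to compound 2 bears on this change, since it also swaps the aryl group on the same saturated ring carbon; that step was modest, a 5.2-fold higher number from compound 1 to compound 2 (0.71 log units; beyond the scatter). Among the compounds with values here, no measured step involves 4-phenylphenyl itself, so its direction is open. The expected step in this assay is a 1.2-fold higher number from compound 2 to compound 3 (0.08 log units; within the scatter), within scatter, with a wide band. Compound 3 is estimated at 4000 nM, range 1200 nM to 14000 nM.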

Compound 3, half-maximal inhibitory concentration: > 10000 nM
Compound 3 was reported as a limit; the forecaster's own chance of this, stated with the estimate: 10%; middle value at least 2.5-fold (0.39 log units) from the limit.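

In this assay, the aryl group on this saturated ring carbon has a wider effect than the first pair showed: 4-phenylphenyl gives an at least 3.0-fold higher number from compound 2 to compound 3 (0.47 log units; beyond the scatter), and the comparison with 3,5-dichlorophenyl gives an at least 15-fold higher number from compound 1 to compound 3 (1.19 log units; beyond the scatter), which is large. Among these three compounds, the only one with two aromatic rings at this position is the one with the highest reported number, so this change is not neutral. From the compounds shown here alone, the result for compound 3 is a limit and not a number, so both steps are lower bounds and its true size stays unknown: the limit of > 10000 nM in this assay, at which 1 of the 3 values shown sits.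

Going by these compounds, whether the second ring itself or its location on the first ring drives this result remains open, and 3-phenylphenyl or 4-isopropylphenyl would separate the two. On these data alone, how far the number would move with a carboxylic acid or an amine on the aryl group also remains open.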